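Cytotoxicity limits in the series, cyclopropylamino to isobutylamino

The compounds below may be only part of what the source reports. "The series", "measured", "known", "first", "only" and "open" are said of these compounds alone.

Measured in an ADME assay on HFF cells (Homo sapiens) for cytotoxicity, with a stated time of 8 days; a lower number here means that less compound is tolerated, a higher number that more compound is tolerated:
- Compound 1 `Nc1nc(OCc2ccccc2)c2ncn(/C=C3/CC3(CO)CO)c2n1`: > 300000 nM (a limit)
- Compound 2 `Nc1nc(NC2CC2)c2ncn(/C=C3/CC3(CO)CO)c2n1`: > 300000 nM (a limit)

Compound 2 stands only at a limit, > 300000 nM, and not at a number. Compound 1 shares that limit, so the evidence so far is the limit of > 300000 nM in this assay, at which 2 of the 2 values shown sit. The next structure is compound 3 `CC(C)CNc1nc(N)nc2c1ncn2/C=C1/CC1(CO)CO`, where isobutyl takes the place of cyclopropyl on a nitrogen on an aromatic ring, cyclopropylamino to isobutylamino (isobutyl in place of cyclopropyl on a nitrogen on an aromatic ring). Going by the values given here, the one measured step, a step that the two limits leave unreadable from compound 1 to compound 2, changes the same place on the core but gives no size to carry over. No step beyond the scatter is therefore expected in this assay, and a further limit is the likeliest report. This expectation rests on compound 2 at > 300000 nM. For compound 3 the estimated half-maximal cytotoxic concentration is 250000 nM, with an expected range of 100000 nM to 300000 nM. The expected step is an at least 1.2-fold lower number from compound 2 to compound 3 (0.07 log units; that floor lies within the scatter).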

Compound 3, half-maximal cytotoxic concentration: > 300000 nM
Compound 3: a limit, no number; the forecaster's own chance of this, stated with the estimate: 70%; middle value at least 1.2-fold (0.07 log units) from the limit.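

Going by these compounds alone, compound 3 is reported only as a limit, so no step among compound 1, compound 2 and compound 3 can be read in this assay. The compounds shown leave open what numerical half-maximal cytotoxic concentration any of the three has, and the record so far is: the limit of > 300000 nM in this assay, at which 3 of the 3 values shown sit.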